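This account rests on a few compounds, and the source may have more. Where it says the series, first, only, none or still open, it means among the compounds named here.

Working notes on the series. Of the compounds shown here, three have been measured in an assay for inhibition of Indoleamine 2,3-dioxygenase 1 (Homo sapiens), with stated times of 10 min and 60 min; a higher number here means a weaker inhibitor, a lower number a stronger inhibitor. Compound 1 `O=[N+]([O-])c1ccccc1CNc1cc(Br)cc2cn[nH]c12` gives > 100000 nM, which is a limit of the assay rather than a number. Among the compounds with values here, compound 2 `O=[N+]([O-])c1ccccc1CNc1cc(C(F)(F)F)cc2[nH]ncc12` gives 14000 nM, the only numerical value in the set so far. Compound 3 `O=[N+]([O-])c1cccc(CNc2cc(C(F)(F)F)cc3[nH]ncc23)c1` gives > 100000 nM, again a limit and not a number. Within the data shown here, compound 3 thus stands at the limit of > 100000 nM in this assay, at which 2 of the 3 values shown sit, together with compound 1, while compound 2 is the one member with a measured number. No step between measured compounds that differ in a single place is available, so the three values can only be set side by side and no cause can be given for any gap.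

Compound 4 `CNC(=O)c1cccc(CNc2cc(C(F)(F)F)cc3[nH]ncc23)c1` has not yet been measured and differs from compound 3 by methylcarbamoyl in place of nitro on an aromatic carbon. Since compound 3 sits at a limit, any step to compound 4 can only be toward a lower number or to another limit; the expected step from compound 3 to compound 4 is an at least 1.6-fold lower number from compound 3 to compound 4 (0.22 log units; that floor lies within the scatter), a modest move toward stronger inhibition, with a real chance that only a limit is again reported. For compound 4 the estimated value in this assay is 60000 nM, with an expected range from 10000 nM to 300000 nM.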

Compound 4, half-maximal inhibitory concentration: > 100000 nM
Compound 4: a limit, no number; the forecaster's own chance of this, stated with the estimate: 55%; middle value at least 1.6-fold (0.22 log units) away from the limit.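

In this assay compound 4 gives > 100000 nM, which is a limit and not a number. Compound 3 also sits at a limit, so no step from compound 3 to compound 4 can be read, and the series now stands as follows: the limit of > 100000 nM in this assay, at which 3 of the 4 values shown sit.

The compounds shown leave open whether methylcarbamoyl in place of nitro on an aromatic carbon changes inhibition at all.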